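The source may hold more compounds than are shown below. What is called first, only, known or untested is meant among the compounds shown, and "the series" means these compounds.

Measured in a functional assay on A549 cells (Homo sapiens) for inhibition, read by CCK-8 assay, with a stated time of 72 h, tested at 1 uM; on this read-out lower numbers stand for less inhibition of growth and higher numbers for more inhibition of growth at the one concentration tested:

- compound 1 `COc1ccc(NC(=O)C2(C(=O)Nc3ccc(Nc4ncc5cc(C(=O)N(C)C)n(C6CCCC6)c5n4)cc3)CC2)cc1`: 74.4%
- compound 2 `CN(C)C(=O)c1cc2cnc(Nc3ccc(NC(=O)C4(C(=O)Nc5cccc(Cl)c5)CC4)cc3)nc2n1C1CCCC1`: 8.3%
- compound 3 `CN(C)C(=O)c1cc2cnc(Nc3ccc(NC(=O)C4(C(=O)Nc5ccc(Cl)c(C(F)(F)F)c5)CC4)cc3)nc2n1C1CCCC1`: 1.1%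

Compound 3, at 1.1%, sits at the low end of these numbers. Its gap to its nearest neighbour is small: a number 7.2 percentage points lower from compound 2 to compound 3 (within the scatter). Its gap to the remaining compound is very wide: a number 73.3 percentage points lower from compound 1 to compound 3 (beyond the scatter).

Compound 4 `CN(C)C(=O)c1cc2cnc(Nc3ccc(NC(=O)C4(C(=O)Nc5cccc(C(F)(F)F)c5)CC4)cc3)nc2n1C1CCCC1` differs from compound 3 in one place (hydrogen in place of chloro on an aromatic carbon). It has hydrogen in place of chloro on an aromatic carbon, ortho to a trifluoromethyl group, so 4-chloro-3-(trifluoromethyl)phenyl becomes 3-(trifluoromethyl)phenyl.

Among the compounds with values here, no measured step makes exactly this change. The closest guide is the swap of one chlorine-bearing ring for another, which stayed within the scatter: a number 7.2 percentage points lower from compound 2 to compound 3 (within the scatter). The large steps, a number 66.1 percentage points lower from compound 1 to compound 2 (beyond the scatter) and a number 73.3 percentage points lower from compound 1 to compound 3 (beyond the scatter), both start from the 4-methoxyphenyl group of compound 1, which compound 4 does not carry. They do show that this ring can matter greatly in this assay, so some room on the upper side is sensible.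

A step beyond the scatter is therefore not expected, and the expected step is small: a number 5.9 percentage points higher from compound 3 to compound 4 (within the scatter). The estimated value for compound 4 is 7%, with an expected range from 0% to 28%.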

Compound 4, percent growth inhibition at one concentration: 15.7%
For compound 4 the middle estimate is 8.7 percentage points below the measured one; low and high end bracket the measured number.
By their numbers in this assay, from the lowest: compounds 3, 2 and 4 (each within the scatter of the next, the first and the last beyond it); then compound 1.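

In this assay, taking away the chloro ortho to the trifluoromethyl group is a change of one atom, and it gives a number 14.6 percentage points higher from compound 3 to compound 4 (beyond the scatter), so a single chlorine on this ring can move the number by more than the scatter, although the step is far smaller than those seen on replacing the 4-methoxyphenyl group. Trifluoromethyl in place of chloro, the other change this compound opens up, gives a number 7.4 percentage points higher from compound 2 to compound 4 (within the scatter), and on this read-out those two groups cannot be told apart on that ring. Even without the chloro, the ring stays far from the 4-methoxyphenyl group, with a number 58.7 percentage points lower from compound 1 to compound 4 (beyond the scatter), so compound 1 remains the only one of the four with a high number, and dropping the chloro recovers only a small part of that gap.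

Nothing measured here bears on why the chloro changes the number. On these data alone, what remains open is whether the high number of compound 1 depends on methoxy itself, which a hydroxyl, an amine or an ethoxy group in its place on that ring would help to test.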